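A Methylated Pyrazole Moved Around Its Ring

A few compounds are considered here, and "the series" means these few. Any claim that something is new, unique, unknown or untested is made for them only; others in the source may bear on it.

Compound 1 `c1cc(-c2cn[nH]c2)c2c(c1)C(c1ncc[nH]1)CC2` gives 319 nM in a functional assay on CHO cells for agonist activity at Alpha-1D adrenergic receptor (Homo sapiens), read by FLIPR and calcium flux; on this read-out higher numbers stand for an effect only at larger amounts of compound and lower numbers for an effect already at smaller amounts.
Compound 2 `Cn1cc(-c2cccc3c2CCC3c2ncc[nH]2)cn1` reaches only the limit of > 10000 nM.
Compound 3 `Cn1ccc(-c2cccc3c2CCC3c2ncc[nH]2)n1` reaches only the limit of > 10000 nM.

Compound 3 thus stands at the upper edge of what this assay reports, a limit rather than a number, and it shares that position with compound 2 (the limit of > 10000 nM in this assay, at which 2 of the 3 values shown sit). Only compound 1, carrying the unmethylated 1H-pyrazol-4-yl, returns a measured value.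

Compound 4 `Cn1nccc1-c1cccc2c1CCC2c1ncc[nH]1` differs from compound 3 in one place: 1-methyl-1H-pyrazol-5-yl in place of 1-methyl-1H-pyrazol-3-yl on an aromatic carbon.

Two measured steps speak to this change. From the unmethylated parent, an at least 31-fold higher number from compound 1 to compound 2 (1.49 log units; beyond the scatter); and likewise an at least 31-fold higher number from compound 1 to compound 3 (1.49 log units; beyond the scatter). Both are large and in the same direction. The step between the two methylated compounds, a step that the two limits leave unreadable from compound 2 to compound 3, cannot be read, because both sit at the limit (the limit of > 10000 nM in this assay, at which 2 of the 3 values shown sit). Compound 4 keeps the methyl on the pyrazole nitrogen, so the expectation is that it stays where compound 2 and compound 3 stand, and no readable step is expected as a step that the limit leaves unreadable from compound 3 to compound 4. Compound 4 is therefore estimated at 15000 nM, with a plausible range from 4000 nM to 60000 nM, most likely reported again only as a limit.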

Compound 4, half-maximal effective concentration: > 10000 nM
Compound 4: no number, only a limit (the forecaster's own chance of this, stated with the estimate: 70%); the middle value is on the limit's open side.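

With compound 4, the third methylated pyrazole on the shared core joins the other two at the edge of what this assay reports, and its distance from the unmethylated parent is large: an at least 31-fold higher number from compound 1 to compound 4 (1.49 log units; beyond the scatter). Within the data shown here, the 1-methyl-1H-pyrazol-5-yl therefore behaves no differently, as far as can be seen here, from the 1-methyl-1H-pyrazol-3-yl and the 1-methyl-1H-pyrazol-4-yl, and among the four compounds only compound 1, with its 1H-pyrazol-4-yl, returns a measured number, with no compound going against this. The steps among compound 2, compound 3 and compound 4 cannot be read, because all three sit at one limit: the limit of > 10000 nM in this assay, at which 3 of the 4 values shown sit.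

The compounds shown leave open how far past that limit compound 2, compound 3 and compound 4 lie, and so whether the three methylated pyrazoles differ at all. They also leave open whether an ethyl on the pyrazole nitrogen, or an amine on a pyrazole carbon, would bring back a measured number.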